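Hydrazone series: chloro to hydrogen step on compound 2

The compounds below may be only part of what the source reports. "The series", "measured", "known", "first", "only" and "open" are said of these compounds alone.

In a functional assay on HOP-92 cells (Homo sapiens) for antiproliferative activity, read by sulforhodamine B assay, with a stated time of 48 h (a higher number here means a weaker inhibitor of growth, a lower number a stronger inhibitor of growth), compound 1 `COc1ccc(OC)c(/C=C/c2nnc(Nc3ccc(Cl)cc3)o2)c1` gives "not determined" (no result reported), so no result is available for it. Among the compounds with values here, compound 2 `COc1ccc(OC)c(/C=C/C(=O)N/N=C/c2ccc(Cl)cc2)c1` is the only member with a number: in this assay compound 2 gives 4430 nM, so it stands alone among the values shown and no comparison is possible yet. Compound 3 `COc1ccc(OC)c(/C=C/C(=O)N/N=C/c2ccccc2)c1` differs from compound 2 by hydrogen in place of chloro on an aromatic carbon. Within the data shown here, no measured pair shows this change, so the expected step of a 1.6-fold higher number from compound 2 to compound 3 (0.20 log units; within the scatter) is a modest loss of growth inhibition, close to the edge of the usual scatter. Compound 3 is accordingly estimated at 7000 nM, with a range from 3000 nM to 16000 nM.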

Compound 3, concentration for 50% growth inhibition: 1560 nM
Compound 3: the middle estimate sits 4.5-fold (0.65 log units) above what was measured, and the stated range ends above it.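

In this assay the change from 4-chlorophenyl to phenyl gives a 2.8-fold lower number from compound 2 to compound 3 (0.45 log units; beyond the scatter) and so a stronger inhibitor of growth, which shows that the chloro group is not required for activity at this position. Compound 3, with hydrogen on this aromatic carbon, is the stronger member of this pair. Nothing available explains the gain.

This single step cannot show whether any group at this carbon lowers growth inhibition or chloro alone does so. An amine or a carboxylic acid in the same place would test this.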